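A few compounds are considered here, and "the series" means these few. Any claim that something is new, unique, unknown or untested is made for them only; others in the source may bear on it.

Compound 2 `COc1cc(OCC=C(C)C)ccc1C(=O)/C=C/c1ccc(Br)cc1` stands highest of the two numbers in an ADME assay on Vero cells (Chlorocebus sabaeus) for cytotoxicity, read by resazurin assay, with a stated time of 72 h (on this read-out lower numbers stand for higher toxicity in this test and higher numbers for lower toxicity in this test), where compound 2 gives 600000 nM; the nearest, compound 1 `COc1cc(OCC=C(C)C)ccc1C(=O)/C=C/c1ccncc1`, gives 16000 nM, separated by a 38-fold higher number from compound 1 to compound 2 (1.57 log units; beyond the scatter). Compound 3 `COc1cc(OCC=C(C)C)ccc1C(=O)/C=C/c1ccc([N+](=O)[O-])cc1` differs from compound 2 by nitro in place of bromo on an aromatic carbon. Among the measured compounds shown here, the only measured step replaced the whole aromatic ring and so offers little guidance for a single substituent exchange on the same ring. For compound 3 the expected step of a 1.7-fold lower number from compound 2 to compound 3 (0.23 log units; within the scatter) is therefore small, staying within the scatter. The estimate for compound 3 is 350000 nM, with a range from 70000 nM to 1500000 nM.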

Compound 3, half-maximal cytotoxic concentration: 600000 nM
Compound 3: the middle estimate sits 1.7-fold (0.23 log units) below what was measured, and the stated range covers the measured number.
By their numbers in this assay, from the lowest: compound 1; then compounds 2 and 3 (each within the scatter of the next).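

In this assay, nitro in place of bromo on this aromatic carbon, para to a large group, gives no change at the digits printed from compound 2 to compound 3 (within the scatter) and so leaves the read-out unmoved, although nitro brings more heavy atoms and hydrogen-bond acceptors. The 4-nitrophenyl ring keeps the same large gap from pyridin-4-yl, with a 38-fold higher number from compound 1 to compound 3 (1.57 log units; beyond the scatter) on that exchange. No evidence is at hand on what lies behind either step.

The compounds shown leave open whether an amine or a carboxylic acid on the same carbon would also leave the number unchanged.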